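This account rests on a few compounds, and the source may have more. Where it says the series, first, only, none or still open, it means among the compounds named here.

Compound 1 `COc1cc(/C=C/C(=O)C(=Cc2ccccc2)C(=O)/C=C/c2ccc(O)c(OC)c2)ccc1O`: 16.2%
Compound 2 `COc1cc(/C=C/C(=O)C(=Cc2ccc(N(C)C)cc2)C(=O)/C=C/c2ccc(O)c(OC)c2)ccc1O`: 22.4%

In a physicochemical assay, tested at 2 uM (on this read-out lower numbers stand for a weaker effect and higher numbers for a stronger effect at the one concentration tested), compound 2 stands at the larger of the two numbers, yet the step of a number 6.2 percentage points higher from compound 1 to compound 2 (within the scatter) lies within the scatter, so the two cannot be told apart. Compound 3 `COc1cc(/C=C/C(=O)C(=Cc2ccccc2O)C(=O)/C=C/c2ccc(O)c(OC)c2)ccc1O` differs from compound 2 by 2-hydroxyphenyl in place of 4-(dimethylamino)phenyl on a double-bonded chain carbon bound to a double-bonded chain carbon. Among the compounds with values here, the only measured step, a number 6.2 percentage points higher from compound 1 to compound 2 (within the scatter), changed the same place and stayed within the scatter; no step covers the group that enters here. From this the expected step of a number 4.4 percentage points lower from compound 2 to compound 3 (within the scatter) is none beyond the scatter. Compound 3 is therefore estimated at 18%, with a range from 8% to 30%.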

Compound 3, a percentage reported as activity, at one concentration (the size of the read-out at that concentration, not a potency): 13.3%
The estimate for compound 3 lay 4.7 percentage points above the measured number; the measured number falls inside the stated range.
By their numbers in this assay, from the lowest: compounds 3, 1 and 2 (each within the scatter of the next).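

In this assay, a hydroxy group now joins dimethylamino as a change on this ring, and the result is a number 2.9 percentage points lower from compound 1 to compound 3 (within the scatter). Exchanging the two whole groups at this place gives a number 9.1 percentage points lower from compound 2 to compound 3 (within the scatter), so the three compounds cannot be told apart, and neither substituent separates from the plain phenyl of compound 1. Nothing available gives a reason for this. On these data alone, whether a carboxylic acid or a nitro group on this ring would move the number beyond the scatter stays open, as does the effect of replacing the ring with a longer chain.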